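The source may report more compounds than this note shows. Statements on the series, on what has been measured and on what is new or still open speak of the compounds shown alone.

Compound 1 `C=Cc1ccc(-c2cc(C)c3ncc(CSCCc4ccccc4)n3c2)cc1` and compound 2 `C=Cc1ccc(-c2cc(C)c3ncc(CSCc4ccccc4)n3c2)cc1` share one core and differ in a single place: phenyl in place of benzyl on a saturated chain carbon bound to a sulfur. In an ADME assay on HEL cells (Homo sapiens) for cytotoxicity, with a stated time of 3 days (a higher number here means that more compound is tolerated, a lower number that less compound is tolerated), compound 1 gives 14 ug/mL, while compound 2 gives 59 ug/mL, so that change produced a 4.2-fold higher number from compound 1 to compound 2 (0.62 log units; beyond the scatter).

Compound 3 `Cc1cc(-n2cccc2)c2ncc(CSCCc3ccccc3)n2c1` rests on a different core; the difference between the core of compound 3 and the core of compound 1 is not broken down here. In this assay compound 3 gives 26 ug/mL, which is the second highest of the three measured numbers, within the scatter of compound 1 and beyond the scatter of compound 2.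

Compound 4 `Cc1cc(-n2cccc2)c2ncc(CSCc3ccccc3)n2c1` has not yet been measured. It stands to compound 3 as compound 2 stands to compound 1: phenyl in place of benzyl on a saturated chain carbon bound to a sulfur. The place of the change is the same in both pairs, so this is the same change made a second time; among these compounds it occurs twice in all.

The expectation for compound 4 rests on that single earlier step. The step expected for compound 4 is a 2.9-fold higher number from compound 3 to compound 4 (0.46 log units; beyond the scatter) in this assay, beside the earlier 4.2-fold higher number from compound 1 to compound 2 (0.62 log units; beyond the scatter). The expected step is held a little smaller than the earlier one because a 4.2-fold higher number from compound 1 to compound 2 (0.62 log units; beyond the scatter) was measured on a different core and stands alone as one example. Compound 4 is therefore estimated at 75 ug/mL, with a range from 35 ug/mL to 160 ug/mL.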

Compound 4, half-maximal cytotoxic concentration: 15 ug/mL
Compound 4: middle estimate off by 5.0-fold (0.70 log units), on the high side, outside the stated range (below it).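

Made a second time, phenyl in place of benzyl on a saturated chain carbon bound to a sulfur gave a 1.7-fold lower number from compound 3 to compound 4 (0.24 log units; within the scatter) in this assay, a step too small to set the two compounds apart. Set beside the first pair, this shows that the rise in tolerated concentration seen on the core of compound 1 did not carry over to the core of compound 3, so the effect of the change in this series depends on the core that bears it: the same change on two cores in this assay, a 4.2-fold higher number (0.62 log units; beyond the scatter) from compound 1 to compound 2 and a 1.7-fold lower number (0.24 log units; within the scatter) from compound 3 to compound 4, 7.3-fold (0.86 log units) apart, beyond the scatter of two such steps

Going by these compounds alone, with only two pairs, this does not show which part of the cores accounts for the gap, nor does it show how the change would behave on any third core, and the step on the core of compound 1 remains a single example.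

The compounds shown leave open whether the same contrast between the two cores would appear with a chain longer than phenethyl on the sulfur, or with an amine or a carboxylic acid on the phenyl ring. They also leave open whether a third core carrying the same benzyl and phenethyl pair would follow the core of compound 1, the core of compound 3, or neither.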